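Swapping a pyrrolidine for a phenylpiperazine: cytotoxicity outlook

A few compounds are considered here, and "the series" means these few. Any claim that something is new, unique, unknown or untested is made for them only; others in the source may bear on it.

Within the data shown here, compound 1 `Cn1c(-c2ccc([N+](=O)[O-])cc2)nc2cc(C(F)(F)F)ccc21` is the first measured compound. In an ADME assay on BHK cells (Mesocricetus auratus) for cytotoxicity, read by MTT assay, with a stated time of 96 h (a higher number here means that more compound is tolerated, a lower number that less compound is tolerated), compound 1 gives only a limit, > 100000 nM.
Compound 2 `Cn1c(-c2ccc(NC(=O)CN3CCCC3)cc2)nc2cc(C(F)(F)F)ccc21` is the second. In this assay compound 2 gives 27000 nM.

Among the measured compounds shown here, compound 2 therefore holds the only definite number; the other value is a limit, and the step of an at least 3.7-fold lower number from compound 1 to compound 2 (0.56 log units; beyond the scatter) is open-ended due to the limit of > 100000 nM in this assay, at which 1 of the 2 values shown sits. Compound 3 `Cn1c(-c2ccc(NC(=O)CN3CCN(c4ccccc4)CC3)cc2)nc2cc(C(F)(F)F)ccc21` differs from compound 2 by 4-phenylpiperazin-1-yl in place of pyrrolidin-1-yl on a saturated chain carbon bound to a carbonyl carbon. For the measured compounds named here, no measured step touches this position, so the change has no precedent here, and the expected step is no more than the scatter, a 1.4-fold lower number from compound 2 to compound 3 (0.13 log units; within the scatter), leaning to a lower number. Compound 3 is thus estimated at 20000 nM, ranging from 7000 nM to 60000 nM.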

Compound 3, half-maximal cytotoxic concentration: 100000 nM
Compound 3: the middle estimate sits 5.0-fold (0.70 log units) below what was measured; measured number above the stated range.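

This position on a saturated chain carbon bound to a carbonyl carbon clearly affects the read-out in this assay: 4-phenylpiperazin-1-yl in place of pyrrolidin-1-yl gives a 3.7-fold higher number from compound 2 to compound 3 (0.57 log units; beyond the scatter). Among these compounds, the earlier step concerned a different place, so this is the first sign that the amine here can be changed without lowering the number.

On these data alone, compound 1 holds only a limit, so its relation to compound 3 cannot be read: the limit of > 100000 nM in this assay, at which 1 of the 3 values shown sits. Whether the change follows the phenyl ring or the piperazine ring stays open, and an unsubstituted piperazine or a morpholine at this place would help separate the two.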